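The source may report more compounds than this note shows. Statements on the series, on what has been measured and on what is new or still open speak of the compounds shown alone.

Compound 1 `Cn1cc(C2=C(c3nn(CCCN4CCCCC4)c4ncccc34)C(=O)N(c3ccccc3)C2=O)c2ccccc21`: 12300 nM
Compound 2 `Cn1cc(C2=C(c3nn(CCn4ccnc4)c4ncccc34)C(=O)N(c3ccccc3)C2=O)c2ccccc21`: 8770 nM
Compound 3 `Cn1cc(C2=C(c3nn(CCCn4cccc4)c4ncccc34)C(=O)NC2=O)c2ccccc21`: > 100000 nM, a limit

In a functional assay on ECa-109 cells (Homo sapiens) for antiproliferative activity, read by MTT assay, with a stated time of 48 h (on this read-out lower numbers stand for stronger inhibition and higher numbers for weaker inhibition), compound 3 stands at the limit of > 100000 nM in this assay, at which 1 of the 3 values shown sits, which is a limit and not a number. Compound 4 `Cn1cc(C2=C(c3n[nH]c4ncccc34)C(=O)NC2=O)c2ccccc21` has hydrogen in place of 3-(1H-pyrrol-1-yl)propyl on an aromatic nitrogen. For the measured compounds named here, the only measured step, a 1.4-fold lower number from compound 1 to compound 2 (0.15 log units; within the scatter), lies within the scatter and swaps a chain end instead of removing the chain, so it offers little guidance here. Any reported number would have to fall under the limit of compound 3, so a lower number is expected, with its size poorly fixed. The expected change is an at least 3.3-fold lower number from compound 3 to compound 4 (0.52 log units; beyond the scatter). For compound 4 the estimate is 30000 nM, with an expected range of 6000 nM to 100000 nM.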

Compound 4, half-maximal inhibitory concentration: 46100 nM
Beside the measured number, compound 4's estimate is 1.5-fold (0.19 log units) below it, within the range that was stated.
By their numbers in this assay, from the lowest: compounds 2 and 1 (each within the scatter of the next); then compound 4. At a limit, above all of these: compound 3.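

In this assay, hydrogen in place of 3-(1H-pyrrol-1-yl)propyl on the aromatic nitrogen gives an at least 2.1-fold lower number from compound 3 to compound 4 (0.33 log units; beyond the scatter), the first step shown that removes the whole chain rather than swapping its end. The size of this step is only a lower bound, as the value of compound 3 is a limit and not a number: the limit of > 100000 nM in this assay, at which 1 of the 4 values shown sits. With no chain at this position, compound 4 still gives a measurable value.

Going by these compounds, whether a methyl group or a chain ending in a carboxylic acid on this nitrogen would give a lower number than hydrogen remains open. Also open, on these data alone, is whether removing the chain has a similar effect when the core carries the phenyl group of compound 1.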